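Acetamido in place of amino on the shared core

A few compounds are considered here, and "the series" means these few. Any claim that something is new, unique, unknown or untested is made for them only; others in the source may bear on it.

Among the three measured compounds, compound 1 `Nc1cccc2c(-c3cccc(NC(=O)c4ccc5c(c4)OCCO5)c3)ccnc12` gives the lowest number in a functional assay on LOX IMVI cells (Homo sapiens) for antiproliferative activity, read by sulforhodamine B assay, with a stated time of 48 h (on this read-out higher numbers stand for weaker inhibition and lower numbers for stronger inhibition), at 460 nM. Compound 3 `COc1ccc(C(=O)Nc2cccc(-c3ccnc4c(NC(C)=O)cccc34)c2)cc1OC` gives 800 nM in this assay, a gap that stays within the scatter, so the two cannot be ordered. Among the compounds with values here, compound 2 `Nc1cccc2c(-c3cccc(NC(=O)c4nccs4)c3)ccnc12` gives 6300 nM; the step of a 14-fold higher number from compound 1 to compound 2 (1.14 log units; beyond the scatter) is the only single-point change measured, and it concerns the amide aryl group, not the core nitrogen.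

Compound 4 `CC(=O)Nc1cccc2c(-c3cccc(NC(=O)c4ccc5c(c4)OCCO5)c3)ccnc12` differs from compound 1 by acetyl in place of hydrogen on a nitrogen on an aromatic ring, with the benzodioxin amide kept. Within the data shown here, no measured step isolates this change. The nearest guide is compound 3, which carries the same acetamido group on the core but a different amide aryl; its value and that of compound 1 sit within the scatter of each other, which suggests that acylation of this nitrogen is tolerated without a large shift in either direction. The expectation is therefore a step of a 1.5-fold higher number from compound 1 to compound 4 (0.18 log units; within the scatter) that stays within the scatter, and compound 4 is estimated at 700 nM, with a range from 300 nM to 1600 nM.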

Compound 4, half-maximal inhibitory concentration: 96 nM
Estimate against measurement, compound 4: 7.3-fold (0.86 log units) above, and the stated range ends above it.
By their numbers in this assay, from the lowest: compound 4; then compounds 1 and 3 (each within the scatter of the next); then compound 2.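

Amino to acetamido on the shared core, with the benzodioxin amide kept, gives in this assay a 4.8-fold lower number from compound 1 to compound 4 (0.68 log units; beyond the scatter) and so shows that acetyl on this nitrogen lowers the number in this pair. The amide aryl still matters with acetamido in place: 2,3-dihydro-1,4-benzodioxin-6-yl in place of 3,4-dimethoxyphenyl gives an 8.3-fold lower number from compound 3 to compound 4 (0.92 log units; beyond the scatter) on the carbonyl carbon. No evidence bears on the origin of either step.

From the compounds shown here alone, it remains open whether the lower number belongs to acetyl alone or also appears with a propionyl group, a methanesulfonyl group or a methyl group on this nitrogen. Also open, going by these compounds, is whether acetamido would shift the number of compound 2, at 6300 nM in the amino form with 1,3-thiazol-2-yl on the carbonyl carbon.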